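Notes on compound 4 against three measured analogues

The compounds below may be only part of what the source reports. "The series", "measured", "known", "first", "only" and "open" are said of these compounds alone.

Measured so far in a functional assay on HOP-62 cells (Homo sapiens) for inhibition, read by sulforhodamine B assay, with a stated time of 48 h; a lower number here means a stronger inhibitor of growth, a higher number a weaker inhibitor of growth:
compound 1 `Nc1cc(N)c2nc(-c3ccccc3)c(Oc3ccc(F)cc3)nc2c1` gives 21400 nM
compound 2 `COc1ccc(CNc2nc3cc(N)cc(N)c3nc2-c2ccccc2)cc1OC` gives 18200 nM
compound 3 `COc1ccc(CNc2nc3cc(N)cc(N)c3nc2-c2ccccc2)cc1` gives 17400 nM

Compound 1 shows the highest of the three numbers, yet its gaps to compound 2 and to compound 3 both lie within the scatter, so the three stand together and none of them can be called the stronger or the weaker inhibitor. Going by the values given here, the only step that can be stated between measured compounds, a 1.0-fold lower number from compound 2 to compound 3 (0.02 log units; within the scatter), also stays within the scatter.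

Compound 4 `COc1ccc(Sc2nc3cc(N)cc(N)c3nc2-c2ccccc2)cc1` arises from compound 1 by the change ((4-methoxyphenyl)sulfanyl in place of 4-fluorophenoxy on an aromatic carbon). Among the compounds with values here, no measured pair alters this part of the shared core, so nothing bears on it directly. Within the data shown here, the sole recorded step concerns hydrogen in place of methoxy on an aromatic carbon and produced no movement in this assay. With the whole set flat, no step beyond the scatter is expected in this assay for compound 4. The expected step is a 1.1-fold lower number from compound 1 to compound 4 (0.05 log units; within the scatter). Compound 4 is estimated at 19000 nM, with a range from 8000 nM to 45000 nM.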

Compound 4, concentration for 50% growth inhibition: < 100000 nM
Compound 4: no number, only a limit (the forecaster's own chance of this, stated with the estimate: 10%); the middle value does not contradict the limit.
By their numbers in this assay, from the lowest: compounds 3, 2 and 1 (each within the scatter of the next).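

Going by these compounds alone, no step from compound 1 to compound 4 can be read: in this assay compound 4 gives < 100000 nM, which is a limit and not a number. From the compounds shown here alone, whether (4-methoxyphenyl)sulfanyl in place of 4-fluorophenoxy moves the number in this assay at all, and in which direction, stays open.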